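Compound 3 as a new urea partner for compound 2

The compounds below may be only part of what the source reports. "The series", "measured", "known", "first", "only" and "open" are said of these compounds alone.

The series rests on two measured compounds. Compound 1, with structure `COc1cc(NC(C)CCCNC(=O)/C=C/c2cc(OC)c(OC)c(OC)c2)c2ncccc2c1`, is reported in an ADME assay on L6 cells (Rattus norvegicus) for cytotoxicity, read by resazurin assay, with a stated time of 70 h (a higher number here means a weaker inhibitor, a lower number a stronger inhibitor), only as a limit, > 210000 nM, as noted in the limit of > 210000 nM in this assay, at which 1 of the 2 values shown sits. Compound 2, with structure `COc1ccc(/C=C/C(=O)NNC(=O)NCCCC(C)Nc2cc(OC)cc3cccnc23)cc1`, gives in this assay a value of 3600 nM. Compound 2 therefore holds the only measured number shown in this assay, the other entry being a limit, so no step between measured compounds can be stated. Compound 3, with structure `COc1cc(NC(C)CCCNC(=O)NNC(=O)Nc2ccc(Cl)cc2)c2ncccc2c1`, differs from compound 2 by a single change: (4-chlorophenyl)amino in place of 2-(4-methoxyphenyl)ethenyl on a carbonyl carbon. Among the compounds with values here, with no measured step in hand, the expectation for this assay is a moderate step toward weaker inhibition. On that basis compound 3 is expected to give about 30000 nM in this assay, within a range from 6000 nM to 210000 nM. The estimated step, from compound 2 to compound 3, is an 8.3-fold higher number from compound 2 to compound 3 (0.92 log units; beyond the scatter).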

Compound 3, half-maximal inhibitory concentration: 91900 nM
Estimate against measurement, compound 3: 3.1-fold (0.49 log units) below; measured number inside the range.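

In this assay, the position on the carbonyl carbon proves sensitive, with (4-chlorophenyl)amino in place of 2-(4-methoxyphenyl)ethenyl giving a 26-fold higher number from compound 2 to compound 3 (1.41 log units; beyond the scatter). Within the data shown here, this is the only step that can be read, and it is large, but the change alters several things at once: the ring substituent, the double bond outside the aromatic rings and the hydrogen-bond donor count. Compound 1 is reported only as a limit, and steps involving it cannot be read: the limit of > 210000 nM in this assay, at which 1 of the 3 values shown sits.

The compounds shown leave open which part of the change carries the step. A (4-methoxyphenyl)amino or plain phenylamino group on the same carbonyl carbon would separate the contribution of the chlorine from that of the nitrogen.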